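Three Amides at the Assay Limit, One Pentyl Analogue

This account rests on a few compounds, and the source may have more. Where it says the series, first, only, none or still open, it means among the compounds named here.

Compound 1 `C=CC1=C(C(=O)NCc2ccccc2)C(c2ccc(OC)cc2)OC1`: in a functional assay on HeLa cells (Homo sapiens) for cytotoxicity, read by MTT assay, with a stated time of 24 h (on this read-out higher numbers stand for weaker inhibition and lower numbers for stronger inhibition), compound 1 gives > 100000 nM, a limit of the assay.
Compound 2 `C=CC1=C(C(=O)Nc2ccccc2)C(c2ccc(OC)cc2)OC1`: compound 2 gives > 100000 nM, again a limit.
Compound 3 `C=CC1=C(C(=O)Nc2ccccc2)C(c2ccc(F)cc2)OC1`: compound 3 gives > 100000 nM, again a limit.

Compound 2 therefore stands at the ceiling of this assay, not at a number, and so do its two neighbours: the limit of > 100000 nM in this assay, at which 3 of the 3 values shown sit. The step from the benzyl amide to the anilide, a step that the two limits leave unreadable from compound 1 to compound 2, cannot be sized, and neither can the step that the two limits leave unreadable from compound 2 to compound 3, since both ends of each are limits.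

Compound 4 `C=CC1=C(C(=O)NCCCCC)C(c2ccc(OC)cc2)OC1` is the next case. Its change is pentyl in place of phenyl on an amide-type nitrogen; cut one bond further out, the difference reads anilino to pentylamino. Within the data shown here, no measured step with a readable size bears on this move; the only two steps that touch compound 2 are unreadable, so nothing here points either up or down.

Compound 4 is therefore expected to sit where compound 2 sits, with a step of a number no higher from compound 2 to compound 4 (the limit leaves the size open) expected to fall within the scatter. Compound 4 is estimated at 100000 nM, with a range from 40000 nM to 300000 nM, most likely reported as a limit.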

Compound 4, half-maximal inhibitory concentration: > 100000 nM
Compound 4 was reported as a limit (the forecaster's own chance of this, stated with the estimate: 85%); the middle value lies on the limit itself.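

No new step can be read: compound 4 is a limit in this assay, as are compound 1 and compound 2, so neither of its two comparisons has a size. All the compounds shown stand at one ceiling: the limit of > 100000 nM in this assay, at which 4 of the 4 values shown sit. The compounds shown leave open how far past that limit each one lies, and whether their amide groups differ in this assay at all.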